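The source may report more compounds than this note shows. Statements on the series, on what has been measured and on what is new or still open speak of the compounds shown alone.

Measured compounds:
compound 2 `O=C(CCCC1CCN(S(=O)(=O)c2ccc3ccccc3c2)CC1)NO`: 1900 nM
compound 3 `O=C(CCCC1CCN(S(=O)(=O)c2cccc3ccccc23)CC1)NO`: 1040 nM
compound 1 `O=C(CCCC1CCN(S(=O)(=O)c2ccc(-c3cnco3)cc2)CC1)NO`: "not determined" (no result reported)

The three compounds share one core and differ only in the group attached to the sulfonyl. In a functional assay on HCT-116 cells (Homo sapiens) for inhibition, read by resazurin assay, with a stated time of 5 days (a lower number here means a stronger inhibitor of growth, a higher number a weaker inhibitor of growth), compound 2 gives 1900 nM, and compound 3 gives 1040 nM; these two values lie within the usual scatter of each other, so neither is set above the other. Compound 1, which carries a 1,3-oxazol-5-yl on a six-membered aromatic ring of carbon only, has no single number in this assay and therefore cannot be placed against compound 2 or compound 3 on the numbers shown.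

Compound 4 `O=C(CCCC1CCN(S(=O)(=O)c2ccccc2)CC1)NO` is the next member. Its relation to compound 1: hydrogen in place of 1,3-oxazol-5-yl on an aromatic carbon. Among the measured compounds shown here, no pair of measured compounds reproduces this change, so its size in this assay is not known from the data. The expectation is a step toward weaker growth inhibition, of a size beyond the scatter, since compound 4 keeps less of the group on the sulfonyl than any measured compound. Compound 4 is estimated to give 3500 nM in this assay, within a range of 1200 nM to 12000 nM.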

Compound 4, concentration for 50% growth inhibition: 2700 nM
For compound 4 the middle estimate is 1.3-fold (0.11 log units) above the measured one; measured number inside the range.
By their numbers in this assay, from the lowest: compounds 3, 2 and 4 (each within the scatter of the next, the first and the last beyond it).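

No new step can be read from compound 4, since its only one-place partner, compound 1, carries no single number. The compounds shown leave open how the 1,3-oxazol-5-yl compares with hydrogen for growth inhibition. No available evidence bears on this result.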